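A few compounds are considered here, and "the series" means these few. Any claim that something is new, unique, unknown or untested is made for them only; others in the source may bear on it.

Measured so far:
- compound 1, `CC[C@@H]1c2cc(Cl)ccc2C(=O)N1c1cncc2c1CCC[C@H]2NC(C)=O`: 334 nM
- compound 2, `CCC1c2cc(Cl)ccc2C(=O)N1c1cccnc1`: 3340 nM
- compound 3, `CC1c2cc(Cl)ccc2C(=O)N1c1cccnc1`: 1250 nM

All three were run in an ADME assay on cells for inhibition of cytochrome P450 11B1, mitochondrial (Homo sapiens), read by HTRF; a lower number here means a stronger inhibitor, a higher number a weaker inhibitor. Compound 1 has the lowest number of the three; compound 3 stands nearest to it and compound 2 furthest, both gaps beyond the scatter. The difference between the core of compound 1 and the core of compound 2 is not broken down here.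

Within the pair of compound 2 and compound 3 one change is made: hydrogen in place of methyl on a saturated chain carbon bound to a saturated ring carbon. It gave a 2.7-fold lower number from compound 2 to compound 3 (0.43 log units; beyond the scatter), a modest step toward a stronger inhibitor.

Compound 4, `CC(=O)N[C@@H]1CCCc2c1cncc2N1C(=O)c2ccc(Cl)cc2[C@H]1C`, is not yet measured. It differs from compound 1 by hydrogen in place of methyl on a saturated chain carbon bound to a saturated ring carbon. This is the same change, read one bond further out as ethyl to methyl, that separates compound 2 from compound 3, and the place is described in the same words for both pairs.

For the measured compounds named here, for compound 4 in this assay a step of about the size seen from compound 2 to compound 3 is expected, that is a 2.6-fold lower number from compound 1 to compound 4 (0.41 log units; beyond the scatter), because compound 1 starts from 334 nM and the one earlier instance of this change gave a 2.7-fold lower number from compound 2 to compound 3 (0.43 log units; beyond the scatter). The expectation rests on a single prior pair, so the range is kept broad. The estimate for compound 4 is 130 nM, expected to lie between 50 nM and 350 nM.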

Compound 4, half-maximal inhibitory concentration: 5140 nM
For compound 4 the middle estimate is 40-fold (1.60 log units) below the measured one, and the stated range ends below it.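

Replacing methyl with hydrogen on a saturated chain carbon bound to a saturated ring carbon, read one bond further out as ethyl to methyl, gave a 15-fold higher number from compound 1 to compound 4 (1.19 log units; beyond the scatter) in this assay, a large step toward a weaker inhibitor. The change does not carry over from one core to the other in this series, and its direction reverses: the same change on two cores in this assay, a 2.7-fold lower number (0.43 log units; beyond the scatter) from compound 2 to compound 3 and a 15-fold higher number (1.19 log units; beyond the scatter) from compound 1 to compound 4, 41-fold (1.61 log units) apart, beyond the scatter of two such steps This shows that the step on the core of compound 2 is no guide to the core of compound 1, but it does not show which difference between the two cores lies behind the reversal, and compound 2 and compound 3 also carry no drawn stereochemistry at the ring carbon bearing the chain, unlike compound 1 and compound 4.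

Left open is how the core of compound 1 responds to other groups at this place, such as a longer chain like propyl or a cyclopropyl ring, and whether ethyl is a particular optimum there or part of a wider trend. Also open, from the compounds shown here alone, is whether such groups would give the same order on the core of compound 2.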